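Methoxy for chloro on a caffeic ester amide

The source may hold more compounds than are shown below. What is called first, only, known or untested is meant among the compounds shown, and "the series" means these compounds.

Compound 1 `O=C(COC(=O)/C=C/c1ccc(O)c(O)c1)NN1CCOCC1`: in a functional assay on HeLa cells (Homo sapiens) for cytotoxicity, read by MTT assay, with a stated time of 72 h (on this read-out higher numbers stand for weaker inhibition and lower numbers for stronger inhibition), compound 1 gives > 200000 nM, a limit of the assay.
Compound 2 `COc1ccc(NC(=O)COC(=O)/C=C/c2ccc(OCc3ccccc3)c(O)c2)cc1`: compound 2 gives > 200000 nM, also a limit.
Compound 3 `O=C(COC(=O)/C=C/c1ccc(O)c(O)c1)Nc1ccc(Cl)cc1`: compound 3 gives 195000 nM.

Compound 3 holds the only number shown in this assay; the two other values are limits. Within the data shown here, its single measured step, an at least 1.0-fold lower number from compound 1 to compound 3 (0.01 log units; that floor lies within the scatter), is a floor that lies within the scatter, and the limit of > 200000 nM in this assay, at which 2 of the 3 values shown sit, marks how little this set moves. Compound 4 `COc1ccc(NC(=O)COC(=O)/C=C/c2ccc(O)c(O)c2)cc1` differs from compound 3 by methoxy in place of chloro on an aromatic carbon. Among the measured compounds shown here, no measured step covers this change. Compound 2 sits at a limit. Compound 4 is therefore expected to show no step beyond the scatter, a 1.3-fold higher number from compound 3 to compound 4 (0.11 log units; within the scatter). Compound 4 is estimated at 250000 nM, between 100000 nM and 600000 nM, and is likely to be reported only as a limit.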

Compound 4, half-maximal inhibitory concentration: > 200000 nM
Compound 4 ended at the assay's limit; the forecaster's own chance of this, stated with the estimate: 70%; the middle value does not contradict the limit.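

Methoxy in place of chloro on an aromatic carbon gives an at least 1.0-fold higher number from compound 3 to compound 4 (0.01 log units; that floor lies within the scatter) in this assay, so this first reading at the position shows no change that can be told from the scatter. The steps from compound 1 and from compound 2 to compound 4 cannot be read, as both ends of each are limits. The set now gathers still more closely at one value: the limit of > 200000 nM in this assay, at which 3 of the 4 values shown sit.

On these data alone, what an amine or a carboxylic acid on this aromatic carbon would do in this assay stays open. So does whether any group there brings the number clear of the limit.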